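A few compounds are considered here, and "the series" means these few. Any claim that something is new, unique, unknown or untested is made for them only; others in the source may bear on it.

The measured compounds and their values in an assay on membranes from brain for binding affinity to adenosine receptor A1 (Rattus norvegicus), read by radioligand binding, tested at 20 uM (on this read-out lower numbers stand for less inhibition and higher numbers for more inhibition at the one concentration tested (going by the name of the read-out)), are:
compound 1, `Cn1c(=O)[nH]c2c(cnn2-c2cccc([N+](=O)[O-])c2)c1=N`, which gives 2%;
compound 2, `Cn1c(=O)[nH]c2c(cnn2-c2cccc(Br)c2)c1=N`, which gives 40%;
compound 3, `Cn1c(=O)[nH]c2c(cnn2-c2cccc(N)c2)c1=N`, which gives 0%.

On these numbers compound 3 holds the lowest value of the three. Its distance to compound 1 is small, a number 2 percentage points lower from compound 1 to compound 3 (within the scatter), so the two cannot be told apart. The only clear separation is a number 40 percentage points lower from compound 2 to compound 3 (beyond the scatter), a large loss when amino takes the place of bromo.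

Compound 4, `Cn1c(=O)[nH]c2c(cnn2-c2cccc(F)c2)c1=N`, is the next member of the series and differs from compound 3 by fluoro in place of amino on an aromatic carbon.

Within the data shown here, two measured steps bear on this change. The reverse of a number 40 percentage points lower from compound 2 to compound 3 (beyond the scatter) shows that a halogen in this place can lift the value strongly; fluoro, like bromo, is a halogen. Against that, a number 2 percentage points lower from compound 1 to compound 3 (within the scatter) shows that a group other than amino at this place need not lift the value at all. Fluoro is not bromo, so the full gain of compound 2 is not assumed, but some rise in this assay is expected, a number 20 percentage points higher from compound 3 to compound 4 (beyond the scatter). Compound 4 is therefore estimated at 20%, with a range from 0% to 45%.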

Compound 4, a percentage reported as inhibition, at one concentration (the size of the read-out at that concentration, not a potency): 44%
Compound 4: the middle estimate sits 24 percentage points below what was measured, within the range that was stated.
By their numbers in this assay, from the lowest: compounds 3 and 1 (each within the scatter of the next); then compounds 2 and 4 (each within the scatter of the next).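

In this assay the two halogen compounds cannot be told apart, with a number 4 percentage points higher from compound 2 to compound 4 (within the scatter) when fluoro takes the place of bromo, so the higher level at this position is not unique to bromo. Fluoro also stands clearly apart from both non-halogen groups, with a number 44 percentage points higher from compound 3 to compound 4 (beyond the scatter) when it replaces amino and a number 42 percentage points higher from compound 1 to compound 4 (beyond the scatter) when it replaces nitro. Among these four compounds the position therefore falls into two levels, with fluoro and bromo on one and amino and nitro on the other.

No measurement offered here explains this separation. As far as these compounds go, it remains open whether chloro, iodo or methoxy at this place would join the halogen level or the level of amino and nitro, and whether fluoro would hold this level elsewhere on the ring.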